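The source may report more compounds than this note shows. Statements on the series, on what has been measured and on what is new or still open speak of the compounds shown alone.

Measured so far:
compound 1 `Cc1cccc(NC(=O)N2CCN(c3nc(N)nc4sc(-c5ccc(F)cc5)nc34)CC2)c1`: in a functional assay on cells (Lymphocyte, Homo sapiens) (a higher number here means a weaker inhibitor, a lower number a stronger inhibitor), compound 1 gives 300 nM.
compound 2 `CCCCCN1CCN(c2nc(N)nc3sc(-c4ccc(F)cc4)nc23)CC1`: in this assay compound 2 gives > 10000 nM, a limit of the assay, not a number.

Compound 2 therefore sits at the limit of > 10000 nM in this assay, at which 1 of the 2 values shown sits, the weaker of the two. Among the measured compounds shown here, the only measured step, an at least 33-fold higher number from compound 1 to compound 2 (1.52 log units; beyond the scatter), bears directly on the next change. Compound 3 `Nc1nc(N2CCN(C(=O)COc3ccccc3)CC2)c2nc(-c3ccc(F)cc3)sc2n1` partly reverses it: (phenoxymethyl)carbonyl in place of pentyl on an amine nitrogen in a ring. The (phenoxymethyl)carbonyl group, like (3-methylphenyl)carbamoyl, places a carbonyl and an aromatic ring on that ring nitrogen, so a drop in this assay is expected, of uncertain size since compound 2 is only a limit. Compound 3 is estimated at 1500 nM, between 300 nM and 10000 nM, an expected step of an at least 6.6-fold lower number from compound 2 to compound 3 (0.82 log units; beyond the scatter).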

Compound 3, half-maximal inhibitory concentration: 90 nM
Compound 3: middle estimate off by 17-fold (1.22 log units), on the high side, outside the stated range (below it).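

Replacing pentyl with (phenoxymethyl)carbonyl gives an at least 110-fold lower number from compound 2 to compound 3 (2.04 log units; beyond the scatter), which more than recovers what pentyl lost. The amino nitrogen of compound 1 is not required for activity in this assay: phenoxymethyl in place of (3-methylphenyl)amino on the carbonyl carbon gives a 3.3-fold lower number from compound 1 to compound 3 (0.52 log units; beyond the scatter). The first of these steps has no fixed size, as compound 2 is only a limit: the limit of > 10000 nM in this assay, at which 1 of the 3 values shown sits.

As far as these compounds go, it remains open whether the ether oxygen or the phenyl ring matters more in compound 3. A plain acetyl or benzoyl group, or a chlorine on the phenoxy ring, would help separate these contributions.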